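The source may report more compounds than this note shows. Statements on the series, on what has been measured and on what is new or still open speak of the compounds shown alone.

Measured in a functional assay on a cell-free system (plasma, Homo sapiens) for inhibition; on this read-out lower numbers stand for stronger inhibition and higher numbers for weaker inhibition:
compound 1 `CC(=O)Oc1ccc(/C=C/C(=O)Nc2nccs2)cc1`: 58100 nM
compound 2 `COc1cc(/C=C/C(=O)Nc2nccs2)cc(OC)c1OC`: 18100 nM
compound 3 `COc1cc(/C=C/C(=O)Nc2nccs2)ccc1OC(C)=O`: 25500 nM

Compound 3 at 25500 nM lies within the scatter of compound 2 and clearly under compound 1, as the modest step of a 2.3-fold lower number from compound 1 to compound 3 (0.36 log units; beyond the scatter) shows. Compound 4 `COc1ccc(/C=C/C(=O)Nc2nccs2)cc1OC` is still unmeasured. It keeps the methoxy of compound 3 and changes acetoxy to methoxy, with methyl in place of acetyl on an oxygen on an aromatic ring.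

Among the compounds with values here, no measured step covers this exact change. Within the data shown here, the one single-place step, a 2.3-fold lower number from compound 1 to compound 3 (0.36 log units; beyond the scatter), is methoxy in place of hydrogen on an aromatic carbon, so it bears only indirectly. Compound 2 carries no acetoxy, yet its value of 18100 nM stays within the scatter of compound 3. A change beyond the scatter in this assay is therefore not expected. The expected step is a 1.2-fold lower number from compound 3 to compound 4 (0.06 log units; within the scatter), with no firm direction. For compound 4 the estimated value is 22000 nM, with an expected range of 10000 nM to 48000 nM.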

Compound 4, half-maximal inhibitory concentration: 54500 nM
Beside the measured number, compound 4's estimate is 2.5-fold (0.39 log units) below it, and the stated range ends below it.
By their numbers in this assay, from the lowest: compounds 2 and 3 (each within the scatter of the next); then compounds 4 and 1 (each within the scatter of the next).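

Methyl in place of acetyl on an oxygen on an aromatic ring is not a silent change on this core in this assay: the result is a 2.1-fold higher number from compound 3 to compound 4 (0.33 log units; beyond the scatter), and this single pair is the only direct reading of acetoxy to methoxy. Compound 4 also gives a second reading of the methoxy change, in the reverse direction, as a 3.0-fold higher number from compound 2 to compound 4 (0.48 log units; beyond the scatter). Methoxy in place of hydrogen on an aromatic carbon therefore now lowers the number consistently across two cores: the same change on two cores in this assay, a 2.3-fold lower number (0.36 log units; beyond the scatter) from compound 1 to compound 3 and a 3.0-fold lower number (0.48 log units; beyond the scatter) from compound 4 to compound 2, 1.3-fold (0.12 log units) apart, within the scatter of two such steps.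

From the compounds shown here alone, whether the acetoxy effect rests on the acetyl carbonyl or on the size of the group remains open, and a free hydroxyl, an ethyl ether or a propanoyl ester on the same oxygen could separate these readings. Whether the acetoxy to methoxy step repeats on a second core is also unresolved.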